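A 2,4-Dichlorophenyl Variant of the Shared Core

The compounds below may be only part of what the source reports. "The series", "measured", "known", "first", "only" and "open" are said of these compounds alone.

Three close analogues sharing one core have been measured in a functional assay on NCI-H1975 cells (Homo sapiens) for inhibition, read by MTT assay, with a stated time of 72 h; on this read-out higher numbers stand for weaker inhibition and lower numbers for stronger inhibition. Compound 1 `C=CC(=O)Nc1cccc(NC(=O)CSc2nc(Nc3ccccc3Cl)c3ccccc3n2)c1` gives 10000 nM. Compound 2 `C=CC(=O)Nc1cccc(NC(=O)CSc2nc(Nc3cccc(OC)c3)c3ccccc3n2)c1` gives 7940 nM, and compound 3 `C=CC(=O)Nc1cccc(NC(=O)CSc2nc(Nc3ccc(F)cc3)c3ccccc3n2)c1` gives 4430 nM. Going by the values given here, compound 3 holds the lowest number of the three, yet only the step of a 2.3-fold lower number from compound 1 to compound 3 (0.35 log units; beyond the scatter) lies beyond the scatter; the steps of a 1.3-fold lower number from compound 1 to compound 2 (0.10 log units; within the scatter) and a 1.8-fold lower number from compound 2 to compound 3 (0.25 log units; within the scatter) do not.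

Compound 4 `C=CC(=O)Nc1cccc(NC(=O)CSc2nc(Nc3ccc(Cl)cc3Cl)c3ccccc3n2)c1` carries the change (2,4-dichlorophenyl in place of 4-fluorophenyl on a nitrogen on an aromatic ring). The measured steps that bear on it are those exchanging one aryl group for another on the same nitrogen, namely a 2.3-fold lower number from compound 1 to compound 3 (0.35 log units; beyond the scatter), a 1.3-fold lower number from compound 1 to compound 2 (0.10 log units; within the scatter) and a 1.8-fold lower number from compound 2 to compound 3 (0.25 log units; within the scatter), all of them small. Compound 1, whose aryl group also carries chlorine, gives the highest number of the set. Compound 4 is therefore expected to move back toward that range, with a step of a 1.6-fold higher number from compound 3 to compound 4 (0.20 log units; within the scatter) in this assay, and its value is estimated at 7000 nM within 2500 nM to 20000 nM.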

Compound 4, half-maximal inhibitory concentration: 5990 nM
For compound 4 the middle estimate is 1.2-fold (0.07 log units) above the measured one; the measured number falls inside the stated range.
By their numbers in this assay, from the lowest: compounds 3, 4, 2 and 1 (each within the scatter of the next, the first and the last beyond it).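

In this assay, replacing 4-fluorophenyl with 2,4-dichlorophenyl on a nitrogen on an aromatic ring gives a 1.4-fold higher number from compound 3 to compound 4 (0.13 log units; within the scatter), and replacing 3-methoxyphenyl with it gives a 1.3-fold lower number from compound 2 to compound 4 (0.12 log units; within the scatter). The comparison with compound 1 adds a different kind of change at this position, chloro in place of hydrogen on an aromatic carbon rather than one aryl group exchanged for another, and it gives a 1.7-fold lower number from compound 1 to compound 4 (0.22 log units; within the scatter). All three steps lie within the scatter, so compound 4 cannot be separated from any other compound, and a chlorine-bearing aryl group does not by itself stay apart from compound 3 as compound 1 does.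

As far as these compounds go, whether a dimethylamino group or a carboxylic acid on this aryl group would shift the number further remains open. Nothing shown here explains these small differences.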